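The source may report more compounds than this note shows. Statements on the series, on what has been measured and on what is new or still open speak of the compounds shown alone.

Three measured members of the series share one core, differing only in the aryl group on the isoxazole-side arm. Compound 1 `O=[N+]([O-])c1ccc(CN2CCC(n3cc(CC(OCc4cc(-c5ccc(F)cc5)no4)c4ccc(Br)cc4)nn3)CC2)cc1` gives 7000 nM in a functional assay on MCF7 cells (Homo sapiens) for cytotoxicity, with a stated time of 48 h; a higher number here means a weaker inhibitor, a lower number a stronger inhibitor. Compound 2 `COc1ccc(-c2cc(COC(Cc3cn(C4CCN(Cc5ccc([N+](=O)[O-])cc5)CC4)nn3)c3ccc(Br)cc3)on2)cc1` gives 4000 nM in this assay, and compound 3 `O=[N+]([O-])c1ccc(CN2CCC(n3cc(CC(OCc4cc(-c5cccc(Br)c5)no4)c4ccc(Br)cc4)nn3)CC2)cc1` gives 6000 nM in this assay. Compound 2 carries the smallest number of the three, but the gaps are slight: a 1.8-fold lower number from compound 1 to compound 2 (0.24 log units; within the scatter) and a 1.5-fold higher number from compound 2 to compound 3 (0.18 log units; within the scatter) both stay inside the scatter, so no ranking is warranted.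

Compound 4 `COc1cccc(-c2cc(COC(Cc3cn(C4CCN(Cc5ccc([N+](=O)[O-])cc5)CC4)nn3)c3ccc(Br)cc3)on2)c1` is not yet measured. It differs from compound 2 by 3-methoxyphenyl in place of 4-methoxyphenyl on an aromatic carbon. For the measured compounds named here, two measured steps touch this arm: a 1.2-fold lower number from compound 1 to compound 3 (0.07 log units; within the scatter), which also moved a substituent between positions on that phenyl, and a 1.5-fold higher number from compound 2 to compound 3 (0.18 log units; within the scatter); neither left the scatter. On that basis the step of a 1.1-fold higher number from compound 2 to compound 4 (0.05 log units; within the scatter) is expected to be small and of no settled direction. Compound 4 is therefore estimated at 4500 nM in this assay, with a range of 2000 nM to 10000 nM.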

Compound 4, half-maximal inhibitory concentration: 7000 nM
Compound 4: the middle estimate sits 1.6-fold (0.19 log units) below what was measured, and the stated range covers the measured number.
By their numbers in this assay, from the lowest: compounds 2, 3, 1 and 4 (each within the scatter of the next).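

Exchanging 4-methoxyphenyl for 3-methoxyphenyl, on the aromatic carbon next to the ring nitrogen, tests placement with the substituent held the same, and in this assay it gives a 1.8-fold higher number from compound 2 to compound 4 (0.24 log units; within the scatter). Methoxy in place of bromo at the same phenyl placement gives a 1.2-fold higher number from compound 3 to compound 4 (0.07 log units; within the scatter), while 3-methoxyphenyl in place of 4-fluorophenyl gives no change at the digits printed from compound 1 to compound 4 (within the scatter), so neither substituent identity nor placement separates compounds 1, 2, 3 and 4 at this position. No supporting data bear on why these steps are so small.

On these data alone, whether any group at this position can leave the scatter remains open, for instance an amine or a carboxylic acid on the phenyl. All four compounds keep the rest of the shared core constant, so these steps say nothing about the other arms in this assay.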